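Series notes: from compound 3 to compound 4

This account rests on a few compounds, and the source may have more. Where it says the series, first, only, none or still open, it means among the compounds named here.

- compound 1 `CC(C)COc1ccc2oc(/C=C/[S+](C)[O-])cc(=O)c2c1`: 1100 nM
- compound 2 `C[S+]([O-])/C=C/c1cc(=O)c2cc(Cl)ccc2o1`: 1700 nM
- compound 3 `CCC(=O)Oc1ccc2oc(/C=C/[S+](C)[O-])cc(=O)c2c1`: 2400 nM

All three values come from a functional assay on A549 cells (Homo sapiens) for cytotoxicity, with a stated time of 48 h; on this read-out lower numbers stand for stronger inhibition and higher numbers for weaker inhibition. Compound 3 stands at 2400 nM, the top of this small set only in relation to compound 1, as a 2.2-fold higher number from compound 1 to compound 3 (0.34 log units; beyond the scatter) shows. Against compound 2 there is no separation: a 1.4-fold higher number from compound 2 to compound 3 (0.15 log units; within the scatter).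

The next compound is compound 4 `C[S+]([O-])/C=C/c1cc(=O)c2cc(OC(=O)C(C)(C)C)ccc2o1`, which keeps the core of compound 3 and carries tert-butyl in place of ethyl on a carbonyl carbon.

Going by the values given here, no measured step changes the alkyl group on this carbonyl carbon, so the evidence is indirect. The nearest change, propanoyl in place of isobutyl on an oxygen on an aromatic ring, gave a 2.2-fold higher number from compound 1 to compound 3 (0.34 log units; beyond the scatter), a modest step. The other two steps replace the whole substituent on the aromatic carbon, and they stay small: a 1.5-fold higher number from compound 1 to compound 2 (0.19 log units; within the scatter) and a 1.4-fold higher number from compound 2 to compound 3 (0.15 log units; within the scatter). Even these larger replacements move the number little, so a change confined to the alkyl group is expected to give no step beyond the scatter, and no direction can be argued from three compounds.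

The expected result is a 1.1-fold lower number from compound 3 to compound 4 (0.04 log units; within the scatter). For compound 4 the estimate is 2200 nM, with an expected range of 1000 nM to 5000 nM.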

Compound 4, half-maximal inhibitory concentration: 1600 nM
For compound 4 the middle estimate is 1.4-fold (0.14 log units) above the measured one; the range from low to high includes it.
By their numbers in this assay, from the lowest: compounds 1, 4, 2 and 3 (each within the scatter of the next, the first and the last beyond it).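

Going by these compounds alone, changing ethyl to tert-butyl on this carbonyl carbon is the first direct test of the alkyl group here, and in this assay it gives no separation (a 1.5-fold lower number from compound 3 to compound 4 (0.18 log units; within the scatter)). With the tert-butyl group in place, the whole substituent also cannot be told apart from the earlier ones, whether ((tert-butyl)carbonyl)oxy replaces chloro on an aromatic carbon (a 1.1-fold lower number from compound 2 to compound 4 (0.03 log units; within the scatter)) or (tert-butyl)carbonyl replaces isobutyl on an oxygen on an aromatic ring (a 1.5-fold higher number from compound 1 to compound 4 (0.16 log units; within the scatter)). Within the data shown here, the only separation in the set therefore remains the one involving the propanoyl compound (a 2.2-fold higher number from compound 1 to compound 3 (0.34 log units; beyond the scatter)), and compound 4 does not share it, so that separation does not extend to both compounds carrying an ester at this position.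

No measurement shown bears on the reason for this flat response to the alkyl group. On these data alone, it remains open whether a longer chain, an amine or a carboxylic acid on this carbonyl carbon would give a step beyond the scatter, and whether any such step would hold in a read-out other than this assay.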